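This account rests on a few compounds, and the source may have more. Where it says the series, first, only, none or still open, it means among the compounds named here.

Measured compounds:
compound 1, `CN(C)Cc1cccc(C(=O)OCCOCn2cnc3c(=O)[nH]c(N)nc32)c1`: 0.117 h
compound 2, `CCN(CC)Cc1cccc(C(=O)OCCOCn2cnc3c(=O)[nH]c(N)nc32)c1`: 0.125 h
compound 3, `CN(C)Cc1ccc(C(=O)OCCOCn2cnc3c(=O)[nH]c(N)nc32)cc1`: 0.55 h

These three compounds were examined in an ADME assay on a cell-free system (plasma, Homo sapiens) for metabolic stability; on this read-out lower numbers stand for a shorter-lived compound and higher numbers for a longer-lived compound. Compound 1 and compound 2 share one core and differ only by diethylamino in place of dimethylamino on a saturated chain carbon bound to an aromatic carbon; that change gave a 1.1-fold higher number from compound 1 to compound 2 (0.03 log units; within the scatter), so the two values say nothing about any ordering between them. Compound 3 carries a different core; the difference between the two cores is not broken down here. In this assay compound 3 gives 0.55 h, the highest of the three numbers, and its gap to compound 2 and to compound 1 lies beyond the scatter.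

Compound 4, `CCN(CC)Cc1ccc(C(=O)OCCOCn2cnc3c(=O)[nH]c(N)nc32)cc1`, has not yet been measured in this assay. It stands to compound 3 as compound 2 stands to compound 1: the change is diethylamino in place of dimethylamino on a saturated chain carbon bound to an aromatic carbon, the same change as between compound 1 and compound 2, at the same place. Since the earlier step was a 1.1-fold higher number from compound 1 to compound 2 (0.03 log units; within the scatter) and lay within the scatter, a step of a 1.1-fold higher number from compound 3 to compound 4 (0.04 log units; within the scatter) is expected from compound 3 to compound 4, again within the scatter. On that basis compound 4 is estimated at 0.6 h, with a range from 0.3 h to 1.2 h. This rests on a single earlier pair and on a core for which no such change has been measured, so the range is kept wide.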

Compound 4, half-life: 0.283 h
Beside the measured number, compound 4's estimate is 2.1-fold (0.33 log units) above it; the whole stated range lies above it.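

In this assay, putting diethylamino in place of dimethylamino on the second core gave a 1.9-fold lower number from compound 3 to compound 4 (0.29 log units; within the scatter), so the half-lives of these two compounds cannot be ordered. Set beside the earlier pair, the change reads the same on both cores, since the gap between the two steps does not exceed what two such steps would scatter by: the same change on two cores in this assay, a 1.1-fold higher number (0.03 log units; within the scatter) from compound 1 to compound 2 and a 1.9-fold lower number (0.29 log units; within the scatter) from compound 3 to compound 4, 2.1-fold (0.32 log units) apart, within the scatter of two such steps This shows that, in the two pairs available, the change moved the half-life by no more than the scatter and that nothing here separates one core from the other in how the change carries over; it does not show that the change has no effect at all, that the two steps are identical in size, or that the same would hold on any further core.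

The compounds shown leave open whether a cyclic amine such as pyrrolidine or morpholine, in place of dimethylamino or diethylamino, would give a half-life that differs beyond the scatter. They also leave open how a longer chain in place of the methylene carbon bearing the amine, or an amide in place of the ester, would read on either core.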